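The source may hold more compounds than are shown below. What is called first, only, known or untested is meant among the compounds shown, and "the series" means these compounds.

Compound 3 `Nc1cc(N)c2nc(-c3ccccc3)c(Sc3ccc(Cl)c(Cl)c3)nc2c1` carries the shared core with a (3,4-dichlorophenyl)sulfanyl group on an aromatic carbon. In a functional assay on K562 cells (Homo sapiens) for inhibition, read by sulforhodamine B assay, with a stated time of 48 h (a lower number here means that less compound is tolerated, a higher number that more compound is tolerated), compound 3 gives < 100000 nM, which is a limit of the assay rather than a number. Compound 1 `Nc1cc(N)c2nc(-c3ccccc3)c(Oc3ccc(Cl)c(Cl)c3)nc2c1` has a 3,4-dichlorophenoxy group on that same aromatic carbon. In this assay compound 1 gives < 100000 nM, again a limit. Compound 2 `CCOC(=O)[C@H](CCC(=O)O)NC(=O)c1ccc(Sc2nc3cc(N)cc(N)c3nc2-c2ccccc2)cc1` gives < 100000 nM in this assay, also a limit. The step that the two limits leave unreadable from compound 1 to compound 3 cannot be read, because of the limit of < 100000 nM in this assay, at which 3 of the 3 values shown sit. Compound 4 `Nc1cc(N)c2nc(-c3ccccc3)c(Sc3ccc(F)cc3)nc2c1` is the next compound, and the change from compound 3 is 4-fluorophenyl in place of 3,4-dichlorophenyl on a sulfur. Going by the values given here, no measured step bears on this change in a readable way, since the only step known, from compound 1 to compound 3, is hidden by the limit. The step that the limit leaves unreadable from compound 3 to compound 4 is therefore an estimate resting only on the three limits, with no size in either direction beyond the scatter to be expected. For compound 4 the expected value in this assay is 30000 nM, with a range from 3000 nM to 100000 nM.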

Compound 4, concentration lethal to 50% of the cells: < 100000 nM
Compound 4 ended at the assay's limit; the forecaster's own chance of this, stated with the estimate: 60%; the middle value is on the limit's open side.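

The steps from compound 1 and compound 3 to compound 4 cannot be read, because all of these compounds sit at the same limit: the limit of < 100000 nM in this assay, at which 4 of the 4 values shown sit.

The compounds shown leave open what values lie behind that limit in this assay, and so whether 4-fluorophenyl in place of 3,4-dichlorophenyl changes anything.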